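Notes on the step from compound 2 to compound 4

This account rests on a few compounds, and the source may have more. Where it says the series, first, only, none or still open, it means among the compounds named here.

In an ADME assay on SW480 cells (Homo sapiens) for cytotoxicity, read by MTT assay, with a stated time of 72 h (a lower number here means a stronger inhibitor, a higher number a weaker inhibitor), the three measured compounds all sit at the weak end. Compound 1 `CCOc1ccc(NC(=O)c2cccc(/C=C3\CC(=O)N(Cc4ccccc4)C3=O)c2)cc1` gives 73200 nM, and compound 3 `CCCCCN1C(=O)C/C(=C\c2cccc(C(=O)Nc3cccc(CC)c3)c2)C1=O` gives 83300 nM; these two values lie within the usual scatter of each other. Compound 2 `COc1ccc(NC(=O)c2cccc(/C=C3\CC(=O)N(c4ccccc4)C3=O)c2)c(C)c1` returns only a limit of the assay, > 100000 nM, so no number is known for it. That places compound 2 at the limit of > 100000 nM in this assay, at which 1 of the 3 values shown sits, and on the numbers shown it cannot be ranked against compound 1 or compound 3. Compound 4 `O=C(Nc1ccc(F)cc1)c1cccc(/C=C2\CC(=O)N(c3ccccc3)C2=O)c1` has not yet been measured. It differs from compound 2 in one place: 4-fluorophenyl in place of 4-methoxy-2-methylphenyl on an amide-type nitrogen, on an amide-type nitrogen whose other neighbour is a carbonyl carbon. Among the compounds with values here, no measured pair in this set differs in one place, so no step size is available to lean on. With every measured value near or at the upper edge of the assay, the expected step from compound 2 to compound 4 is an at least 1.1-fold lower number from compound 2 to compound 4 (0.04 log units; that floor lies within the scatter), that is, none beyond the scatter. Compound 4 is therefore estimated at 90000 nM, within 40000 nM to 200000 nM, and a limit rather than a number remains a real possibility.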

Compound 4, half-maximal inhibitory concentration: > 100000 nM
Compound 4 was reported as a limit; the forecaster's own chance of this, stated with the estimate: 45%; at least 1.1-fold (0.04 log units) between middle value and limit.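

Compound 2 and compound 4 are both reported only as limits of the assay, so no step can be read between them: the limit of > 100000 nM in this assay, at which 2 of the 4 values shown sit. The compounds shown leave open whether 4-fluorophenyl in place of 4-methoxy-2-methylphenyl on the amide-type nitrogen changes the value at all.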